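The compounds below may be only part of what the source reports. "The series", "measured", "known", "first", "only" and "open" are said of these compounds alone.

For the measured compounds named here, in a functional assay on P388D1 cells (Homo sapiens) for antiproliferative activity, read by sulforhodamine B assay, with a stated time of 48 h (a higher number here means a weaker inhibitor, a lower number a stronger inhibitor), three compounds built on a shared core have numbers so far. Compound 2 `O=C1NCCN1c1ccc(S(=O)(=O)Nc2cccc(Br)c2)cc1`, which carries a 3-bromophenyl group, gives 90 nM. Compound 3 `O=C1NCCN1c1ccc(S(=O)(=O)Nc2cccc(Cl)c2)cc1` gives 78 nM, and compound 1 `COc1cc(NS(=O)(=O)c2ccc(N3CCNC3=O)cc2)cc(OC)c1OC` gives 38 nM. Compound 2 therefore stands level with compound 3 within the scatter, and its number is higher than that of compound 1.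

Compound 4 `COc1cccc(NS(=O)(=O)c2ccc(N3CCNC3=O)cc2)c1` has methoxy in place of bromo on an aromatic carbon, meta to a large group (methoxy in place of bromo on an aromatic carbon). Going by the values given here, only one measured step changes this same group: a 1.2-fold lower number from compound 2 to compound 3 (0.06 log units; within the scatter). That swap of chloro for bromo barely moved the number, but it does not introduce methoxy. The only hint about methoxy comes from compound 1, which carries methoxy groups and gives 38 nM, though it differs from compound 4 in more than one place. A small move towards a lower number therefore seems likely, with nothing expected beyond the scatter. In this assay the expected step is a 1.3-fold lower number from compound 2 to compound 4 (0.11 log units; within the scatter). The estimate for compound 4 is 70 nM, with an expected range from 30 nM to 170 nM.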

Compound 4, half-maximal inhibitory concentration: 250 nM
Beside the measured number, compound 4's estimate is 3.6-fold (0.55 log units) below it; the measured number lies above the stated range.
By their numbers in this assay, from the lowest: compound 1; then compounds 3 and 2 (each within the scatter of the next); then compound 4.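

In this assay, this position does not treat all three groups alike: methoxy in place of bromo gives a 2.8-fold higher number from compound 2 to compound 4 (0.44 log units; beyond the scatter) and methoxy in place of chloro gives a 3.2-fold higher number from compound 3 to compound 4 (0.51 log units; beyond the scatter), so compound 4 is the weaker inhibitor in both comparisons. For the compounds shown here, the earlier swap of chloro for bromo stayed within the scatter, whereas these steps are the first at this position to go beyond it, showing that the number here can respond to which group is attached. No measurement at hand shows why methoxy behaves differently from the two halogens.

On these data alone, whether an amine or a fluoro group at this position would fall level with the halogens or nearer to methoxy remains open. It is also unclear whether the oxygen or the added carbon of methoxy matters more, a question that a hydroxyl or an ethyl group could help to separate.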